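A few compounds are considered here, and "the series" means these few. Any claim that something is new, unique, unknown or untested is made for them only; others in the source may bear on it.

Compound 1 `COc1cccc(/C=N/NC(=O)CSc2nnc(-c3ccncc3)o2)c1` holds the highest of the two numbers recorded so far in an ADME assay on NIH3T3 cells (Mus musculus) for cytotoxicity, read by MTT assay, with a stated time of 24 h (a lower number here means a stronger inhibitor, a higher number a weaker inhibitor), giving 179000 nM, with compound 2 sitting within the scatter of it. Compound 2 `O=C(CSc1nnc(-c2ccncc2)o1)N/N=C/c1ccc(O)c(O)c1` gives 154000 nM, so that a 1.2-fold lower number from compound 1 to compound 2 (0.07 log units; within the scatter) stayed within the scatter. Compound 3 `COc1cc(/C=N/NC(=O)CSc2nnc(-c3ccncc3)o2)ccc1O` differs from compound 1 by hydroxy in place of hydrogen on an aromatic carbon. For the measured compounds named here, the only measured step touching the same aromatic ring, a 1.2-fold lower number from compound 1 to compound 2 (0.07 log units; within the scatter), changed nothing beyond the scatter, so no step beyond the scatter is expected here either, a 1.1-fold lower number from compound 1 to compound 3 (0.02 log units; within the scatter). Compound 3 is therefore estimated at 170000 nM, within a range of 90000 nM to 320000 nM.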

Compound 3, half-maximal inhibitory concentration: 148000 nM
Estimate against measurement, compound 3: 1.1-fold (0.06 log units) above, within the range that was stated.
By their numbers in this assay, from the lowest: compounds 3, 2 and 1 (each within the scatter of the next).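

Hydroxy para to a large group and ortho to a methoxy group is accepted in this assay with no shift beyond the scatter: a 1.2-fold lower number from compound 1 to compound 3 (0.08 log units; within the scatter). Methyl in place of hydrogen on an oxygen on the aromatic ring also stays within the scatter, with a 1.0-fold lower number from compound 2 to compound 3 (0.02 log units; within the scatter), so this ring position and this oxygen have both been read without a real change in the number. No available data bear on a cause for these results.

From the compounds shown here alone, whether an amine or a carboxylic acid at this position would move the number beyond the scatter stays open. So does the effect of a longer chain in place of methyl on the oxygen.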